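Triazole substituent changes on the shared core: cytotoxicity notes

This account rests on a few compounds, and the source may have more. Where it says the series, first, only, none or still open, it means among the compounds named here.

Measured compounds:
- compound 1 `COc1nc2ccc(Br)cc2cc1C(c1ccccc1)n1cc(C2CC2)nn1`: 21.8%
- compound 2 `CCCCc1cn(C(c2ccccc2)c2cc3cc(Br)ccc3nc2OC)nn1`: 5.46%
- compound 3 `COc1nc2ccc(Br)cc2cc1C(c1ccccc1)n1cc(-c2ccc(OC(F)(F)F)cc2)nn1`: 11.7%

In an ADME assay on PANC-1 cells (Homo sapiens) for cytotoxicity, read by sulforhodamine B assay, with a stated time of 48 h, tested at 10 uM (on this read-out higher numbers stand for more inhibition at the one concentration tested (going by the name of the read-out) and lower numbers for less inhibition), compound 1 gives 21.8% and stands highest of the three numbers; compound 3 sits nearest and compound 2 furthest, both beyond the scatter. Replacing the cyclopropyl group on the triazole ring gave a number 16.3 percentage points lower from compound 1 to compound 2 (beyond the scatter) and a number 10.1 percentage points lower from compound 1 to compound 3 (beyond the scatter). Between the two replacements themselves the gap was a number 6.2 percentage points higher from compound 2 to compound 3 (within the scatter).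

Compound 4 `COc1nc2ccc(Br)cc2cc1C(c1ccccc1)n1cc(CCCCCO)nn1` has not been measured. It differs from compound 1 by 5-hydroxypentyl in place of cyclopropyl on an aromatic carbon. Both steps away from the cyclopropyl group in compound 1 went downward, and the butyl chain in compound 2 sits lowest, so the 5-hydroxypentyl chain is expected to give a lower number as well, of a size near the steps already seen. The expected step is a number 12.8 percentage points lower from compound 1 to compound 4 (beyond the scatter). Compound 4 is estimated at 9%, with a range from 0% to 20%.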

Compound 4, a percentage reported as inhibition, at one concentration (the size of the read-out at that concentration, not a potency): 19.6%
Estimate against measurement, compound 4: 10.6 percentage points below; low and high end bracket the measured number.
By their numbers in this assay, from the lowest: compounds 2, 3, 4 and 1 (each within the scatter of the next, the first and the last beyond it).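

In this assay, an open chain on this aromatic carbon does not by itself bring a step beyond the scatter away from the cyclopropyl group: 5-hydroxypentyl gives a number 2.2 percentage points lower from compound 1 to compound 4 (within the scatter), against a number 16.3 percentage points lower from compound 1 to compound 2 (beyond the scatter) for butyl. The change from the butyl chain to the 5-hydroxypentyl chain gives a number 14.1 percentage points higher from compound 2 to compound 4 (beyond the scatter), so the chain's make-up bears on the read-out at this position. The 4-(trifluoromethoxy)phenyl group and the 5-hydroxypentyl chain are not separated, with a number 7.9 percentage points higher from compound 3 to compound 4 (within the scatter).

Nothing at hand explains these steps. Compound 4 differs from compound 2 in both chain length and the hydroxyl group. A plain pentyl chain, a shorter hydroxyalkyl chain, or an amine or carboxylic acid in place of the hydroxyl group would be needed to tell these apart.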